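This account rests on a few compounds, and the source may have more. Where it says the series, first, only, none or still open, it means among the compounds named here.

Working notes on the series: three compounds sharing one core have numbers in a functional assay on MCF7 cells (Homo sapiens) for cytotoxicity, read by MTT assay, with a stated time of 48 h; a higher number here means a weaker inhibitor, a lower number a stronger inhibitor. Compound 3 `CC(=NNC(=S)Nc1ccccc1)c1ccccn1`, without a halogen on the aromatic ring, gives 0.18 nM. Compound 1 `CC(=NNC(=S)Nc1cccc(F)c1)c1ccccn1`, the fluoro member, gives 9 nM. Compound 2 `CC(=NNC(=S)Nc1cccc(I)c1)c1ccccn1`, the iodo member, gives 45 nM, the highest number of the three and so the weakest inhibitor here. The measured steps are a 5.0-fold higher number from compound 1 to compound 2 (0.70 log units; beyond the scatter), a 50-fold lower number from compound 1 to compound 3 (1.70 log units; beyond the scatter) and a 250-fold lower number from compound 2 to compound 3 (2.40 log units; beyond the scatter).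

Compound 4 `C/C(=N/NC(=S)Nc1cccc(I)c1)c1ccccn1` is next to be measured, and the change from compound 2 is the two compounds have the same atoms and bonds; at least one stereo element is drawn with a configuration in one of them and without one in the other: 1 of 1 stereo elements differ; a double bond is drawn without a configuration in compound 2 and Z in compound 4: a double bond is drawn without a configuration in compound 2 and Z in compound 4. All three measured steps exchange a group on an aromatic carbon, whereas here the atoms and bonds stay the same. None of those steps therefore measures this change, and their sizes do not carry over. No step beyond the scatter is expected in this assay, so the expectation is anchored on compound 2 at 45 nM.

The expected step is no change at the digits printed from compound 2 to compound 4 (within the scatter). For compound 4 the estimated value is 45 nM, with an expected range of 15 nM to 135 nM.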

Compound 4, half-maximal inhibitory concentration: 45 nM
Compound 4: middle estimate and measured number agree at the digits printed, and the stated range covers the measured number.
By their numbers in this assay, from the lowest: compound 3; then compound 1; then compounds 2 and 4 (each within the scatter of the next).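

In this assay, the series now has a step that exchanges no group on an aromatic carbon and touches only the configuration drawn at a double bond, and it reads no change at the digits printed from compound 2 to compound 4 (within the scatter). For the iodo member, then, drawing this double bond as Z leaves the number within the scatter, a different outcome from the exchanges on the aromatic carbon, all of which lie beyond it. This reading rests on a single pair, and the drawing alone does not establish whether the material behind compound 2 matches that of compound 4; the one difference on which the comparison stands is this: the fact that one of compounds 2 and 4 is drawn with a defined configuration and the other without, at the place where they differ.

Still open, from the compounds shown here alone, is how the E configuration at this double bond would read in this assay, and whether the Z drawing would also leave the number within the scatter on the fluoro member or on the member without a halogen. Also open, going by these compounds, is how a methoxy group or an amine in place of the iodo on the aromatic carbon would compare with the hydrogen of compound 3 at 0.18 nM in this assay.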